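The compounds below may be only part of what the source reports. "The series", "measured", "known", "first", "only" and "open" are said of these compounds alone.

Four compounds share one large core and differ in the group that sits at one end of a chain of double bonds. Compound 1 `COc1cc(/C=C/C(=O)/C=C/c2ccco2)ccc1OCc1cn(CCCCOc2cc(=O)oc3ccccc23)nn1` and compound 2 `COc1cc(/C=C/C(=O)/C=C/c2cc(OC)c(OC)c(OC)c2)ccc1OCc1cn(CCCCOc2cc(=O)oc3ccccc23)nn1` were tested in a functional assay on THP-1 cells (Homo sapiens) for inhibition, read by sulforhodamine B assay, with a stated time of 48 h, tested at 50 uM; on this read-out lower numbers stand for less inhibition of growth and higher numbers for more inhibition of growth at the one concentration tested. Compound 1 gives 49%, and compound 2 gives 65%. The change between them is furan-2-yl in place of 3,4,5-trimethoxyphenyl on a double-bonded chain carbon bound to a double-bonded chain carbon, and it produced a number 16 percentage points lower from compound 2 to compound 1 (beyond the scatter). Compound 3 `COc1cc(/C=C/C(=O)/C=C/c2cc(OC)c(OC)c(OC)c2)ccc1OCc1cn(CCCCCOc2cc(=O)oc3ccccc23)nn1` carries the same end group as compound 2 but a different linker within the core; the difference between the two cores is not broken down here. In this assay compound 3 gives 55%, which lies close to the numbers of both compound 1 and compound 2.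

Compound 4 `COc1cc(/C=C/C(=O)/C=C/c2ccco2)ccc1OCc1cn(CCCCCOc2cc(=O)oc3ccccc23)nn1` has not been measured. Its change relative to compound 3 is furan-2-yl in place of 3,4,5-trimethoxyphenyl on a double-bonded chain carbon bound to a double-bonded chain carbon, which is the same change that turned compound 2 into compound 1, at the same place. For compound 4 the expected step in this assay is a number 16 percentage points lower from compound 3 to compound 4 (beyond the scatter). This expectation rests on the earlier step, a number 16 percentage points lower from compound 2 to compound 1 (beyond the scatter), made by the same change, with the assumption that the step carries over across the two cores. Because compound 3 gives 55%, compound 4 is estimated to reach about 39%, with a plausible range from 25% to 52%.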

Compound 4, percent growth inhibition at one concentration: 39%
Compound 4: middle estimate and measured number agree at the digits printed; the measured number falls inside the stated range.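

In this assay, putting furan-2-yl in place of 3,4,5-trimethoxyphenyl gives a number 16 percentage points lower from compound 3 to compound 4 (beyond the scatter), and this step can be set directly beside the earlier one: the same change on two cores in this assay, a number 16 percentage points lower (beyond the scatter) from compound 2 to compound 1 and a number 16 percentage points lower (beyond the scatter) from compound 3 to compound 4, 0 percentage points apart, within the scatter of two such steps For these two pairs, then, the change behaves the same way on both cores: the furan-2-yl compound inhibits growth less than its 3,4,5-trimethoxyphenyl partner, and the size of the step does not depend on which of the two linkers is present. Within the data shown here, this does not show a general rule, as it rests on only two pairs whose cores are closely related, in one cell line at one concentration, and it does not explain why the two end groups differ.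

The compounds shown leave open whether the same step would appear on a core with a longer chain in the linker, or how other end groups, such as thiophen-2-yl or a phenyl ring carrying an amine, would compare with these two. Also open, from the compounds shown here alone, is how the linker change alone acts on growth inhibition, and whether the step between the end groups would hold at other concentrations.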